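Swapping a sulfonylpiperidine for a tetrazolylphenyl group

This account rests on a few compounds, and the source may have more. Where it says the series, first, only, none or still open, it means among the compounds named here.

Compound 1 `CC(C)(C)OC(=O)N1CCN(c2ccc(OCc3ccc(S(C)(=O)=O)cc3)cn2)CC1`: 253 nM
Compound 2 `CC(C)(C)OC(=O)N1C[C@@H]2CC[C@H]1CN2c1ncc(OCc2ccc(S(C)(=O)=O)cc2)cn1`: > 30000 nM
Compound 3 `C[C@@H]1CN(C(=O)OC(C)(C)C)CCN1c1ncc(OCC2CCN(S(C)(=O)=O)CC2)cn1`: 78 nM

Of the compounds shown here, three have been tested in a functional assay for agonist activity at Glucose-dependent insulinotropic receptor (Mus musculus), read by HTRF and cAMP accumulation, with a stated time of 45 min; on this read-out lower numbers stand for an effect already at smaller amounts and higher numbers for an effect only at larger amounts of compound. Compound 1 gives 253 nM. Compound 2 reaches only a limit of the assay, > 30000 nM, so no number is known for it. That limit is the limit of > 30000 nM in this assay, at which 1 of the 3 values shown sits. Compound 3 gives 78 nM, the lower of the two numbers, and its gap to compound 1 lies beyond the usual scatter of repeated measurements.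

Compound 4 `C[C@@H]1CN(C(=O)OC(C)(C)C)CCN1c1ncc(OCc2ccc(-n3cnnn3)cc2)cn1` has not yet been measured. It differs from compound 3 in one place: 4-(1H-tetrazol-1-yl)phenyl in place of 1-(methylsulfonyl)piperidin-4-yl on a saturated chain carbon bound to an oxygen on an aromatic ring. Among the compounds with values here, no pair of measured compounds shows this exact change, so its size cannot be read off directly. Compound 1 does carry an aromatic ring at that place, but it sits in a different core and is not a single-change comparison, and the gap between compound 1 and compound 3 also reflects those other differences. I therefore expect a step of modest size, close to the scatter, with no firm direction. For compound 4 the expected value is 150 nM, with a range from 30 nM to 800 nM. The expected step is a 1.9-fold higher number from compound 3 to compound 4 (0.28 log units; within the scatter).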

Compound 4, half-maximal effective concentration: 33 nM
Compound 4: the middle estimate sits 4.5-fold (0.66 log units) above what was measured; low and high end bracket the measured number.
By their numbers in this assay, from the lowest: compound 4; then compound 3; then compound 1. At a limit, above all of these: compound 2.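

In this assay, on the shared core, putting 4-(1H-tetrazol-1-yl)phenyl in place of 1-(methylsulfonyl)piperidin-4-yl gives a 2.4-fold lower number from compound 3 to compound 4 (0.37 log units; beyond the scatter). This is the only single-change comparison among the compounds shown, and it reveals that this place, on a saturated chain carbon bound to an oxygen on an aromatic ring, accepts two very different groups: a six-membered non-aromatic ring gives way to a six-membered aromatic ring carrying a five-membered aromatic ring, and the effect still appears at smaller amounts of compound. Nothing measured here explains why the change runs in this direction.

Within the data shown here, this one step, on one core, cannot say whether the same swap would act alike on the cores of compound 1 or compound 2, and no step to either compound can be read, since each differs from the others in more than one place. It also leaves open which part of the entering group matters, a question that a plain phenyl, or a phenyl carrying a carboxylic acid or a nitrile in place of the tetrazole, could help to settle.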